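Adding a Short Chain to a Weak Inhibitor

The source may hold more compounds than are shown below. What is called first, only, known or untested is meant among the compounds shown, and "the series" means these compounds.

compound 1: `Cn1c(Cc2nn(C)c(=O)c3ccccc23)nnc1SCC(=O)Nc1ccc(Cl)cc1Cl` gives 21100 nM in an assay on 32D cells for inhibition of interleukin-15 (Mus musculus), read by resazurin assay, with stated times of 30 min and 2.5 days, in the presence of a further agent that is not named here; a higher number here means a weaker inhibitor, a lower number a stronger inhibitor
compound 2: `CCOC(CCn1c(Cc2nn(C)c(=O)c3ccccc23)nnc1SCC(=O)Nc1ccc(Cl)cc1Cl)OCC` reaches only the assay limit, > 30000 nM
compound 3: `Cn1nc(Cc2nnc(SCC(=O)Nc3ccc(Cl)cc3Cl)n2CCC(=O)O)c2ccccc2c1=O` reaches only the assay limit, > 30000 nM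

Compound 1 is the only one of the three with an actual number rather than a limit in this assay, and that number already marks a weak inhibitor. Compound 2 and compound 3 each carry a chain in place of a hydrogen on a saturated chain carbon bound to an aromatic nitrogen, and both sit at the limit of > 30000 nM in this assay, at which 2 of the 3 values shown sit. The step of an at least 1.4-fold higher number from compound 1 to compound 2 (0.15 log units; that floor lies within the scatter) and the step of an at least 1.4-fold higher number from compound 1 to compound 3 (0.15 log units; that floor lies within the scatter) are therefore known only as floors, and each floor lies within the scatter; the true steps may well be larger.

Compound 4, `Cn1c(Cc2nn(CCC=O)c(=O)c3ccccc23)nnc1SCC(=O)Nc1ccc(Cl)cc1Cl`, has not yet been measured. It differs from compound 1 by formylmethyl in place of hydrogen on a saturated chain carbon bound to an aromatic nitrogen. The two measured steps both add a chain at this kind of place, and both ended at the limit, so the expectation is that the step of a 1.3-fold higher number from compound 1 to compound 4 (0.12 log units; within the scatter) goes toward a higher number, or at most stays within the scatter. Compound 4 is therefore estimated at 28000 nM, within 10000 nM to 80000 nM, with a fair chance that this assay again reports only its limit.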

Compound 4, half-maximal inhibitory concentration: 30000 nM
Compound 4: middle estimate off by 1.1-fold (0.03 log units), on the low side; the measured number falls inside the stated range.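

Going by these compounds alone, compound 1 carries two methyl groups on aromatic nitrogens, and the new chain of compound 4 stands on the one left untouched in compound 2 and compound 3, so this is the first look at that second place. In this assay, on these data alone, the change gives a 1.4-fold higher number from compound 1 to compound 4 (0.15 log units; within the scatter), so methyl to 2-formylethyl at this place produces no readable change, and the size of any effect stays unknown. Unlike the earlier chains, this one also yields an actual number rather than a limit, while compound 2 and compound 3 remain limits, not numbers: the limit of > 30000 nM in this assay, at which 2 of the 4 values shown sit.

None of the compounds shown has a value clearly better than that of compound 1, so it remains open whether anything at this place can give a lower number. A carboxylic acid or an amine at the end of this chain, or a longer chain, would test whether the group at the chain's end matters here or whether this place simply accepts such additions without a readable change.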